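From Propyl to Cyclobutyl on the Amine Nitrogen

This account rests on a few compounds, and the source may have more. Where it says the series, first, only, none or still open, it means among the compounds named here.

Going by the values given here, in an ADME assay on Caco-2 cells (Homo sapiens) for permeability, read by LC-MS, with a stated time of 2 h (on this read-out lower numbers stand for lower permeability and higher numbers for higher permeability), compound 1 `CCCN(Cc1ccc(OCCn2c(=O)ccn(C)c2=O)c(C)c1)C(CC(=O)O)c1ccc(Cl)cc1` gives 3.2 nm/s, while compound 2 `CCCN(Cc1ccc(OCCn2c(=O)ccn(C)c2=O)c(OC)c1)C(CC(=O)O)c1ccc(Cl)cc1` gives 1 nm/s, the lower of the two numbers measured so far. Compound 3 `COc1cc(CN(C2CCC2)C(CC(=O)O)c2ccc(Cl)cc2)ccc1OCCn1c(=O)ccn(C)c1=O` keeps the rest of compound 2 and changes one group: cyclobutyl in place of propyl on an amine nitrogen. In words, cyclobutyl replaces propyl on an amine nitrogen.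

Among the compounds with values here, only one measured step is available, a 3.2-fold lower number from compound 1 to compound 2 (0.51 log units; beyond the scatter), which came from methoxy in place of methyl on an aromatic carbon. That modest step happened at a different place in the structure, so it offers no direct test of the new change. With no evidence for a direction in this assay, no shift beyond the usual scatter is expected. The expected step is a 1.2-fold higher number from compound 2 to compound 3 (0.08 log units; within the scatter). Compound 3 is estimated at 1.2 nm/s, with an expected range from 0.5 nm/s to 3 nm/s.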

Compound 3, apparent permeability: 1.7 nm/s
Estimate against measurement, compound 3: 1.4-fold (0.15 log units) below; low and high end bracket the measured number.
By their numbers in this assay, from the lowest: compounds 2, 3 and 1 (each within the scatter of the next, the first and the last beyond it).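

Moving from the propyl chain to the cyclobutyl ring on the amine nitrogen adds one carbon and closes a four-membered ring, and in this assay this gives a 1.7-fold higher number from compound 2 to compound 3 (0.23 log units; within the scatter) and so leaves the two compounds indistinguishable on this read-out. Going by these compounds alone, this is the first measured look at the amine nitrogen, and it differs from the earlier change on the aromatic carbon, where the shift was a 3.2-fold lower number from compound 1 to compound 2 (0.51 log units; beyond the scatter) and thus a real difference. No supporting measurement is available to explain this result.

The compounds shown leave open whether other groups on this nitrogen, such as a cyclopropyl ring, a cyclopentyl ring or a longer butyl chain, would also stay close to compound 2. Also open, going by these compounds, is how the cyclobutyl ring reads out with methyl in place of methoxy on the aromatic carbon, the form carried by compound 1.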